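The source may hold more compounds than are shown below. What is called first, only, known or untested is meant among the compounds shown, and "the series" means these compounds.

Compound 3 `N#Cc1cc(C(=O)N2CS(=O)(=O)c3ccccc32)cc(C2CC2)c1O` gives 19200 nM in an assay on tissue (RPTEC cells) for inhibition of solute carrier family 22 member 12 (Homo sapiens), read by scintillation counting, with stated times of 15 min and 2 h (a lower number here means a stronger inhibitor, a higher number a weaker inhibitor), the highest of the two numbers shown; compound 1 `N#Cc1cc(C(=O)N2CCc3ccccc32)ccc1O` gives 2500 nM. Compound 2 `COc1cc(C(=O)N2CCc3ccccc32)cc(C#N)c1O` reaches only a limit of the assay, > 100000 nM. The new compound 4 `N#Cc1cc(C(=O)N2CS(=O)(=O)c3ccccc32)cc(Cl)c1O` differs from compound 3 by chloro in place of cyclopropyl on an aromatic carbon. Among the measured compounds shown here, the one measured step, an at least 40-fold higher number from compound 1 to compound 2 (1.60 log units; beyond the scatter), also put a substituent on this ring and weakened binding strongly, as the limit of > 100000 nM in this assay, at which 1 of the 3 values shown sits, marks; compound 3 already carries a group there, so the swap to chloro is expected to be a small step in this assay, within or near the scatter. Compound 4 is therefore estimated at 12000 nM, between 3000 nM and 45000 nM, a change of a 1.6-fold lower number from compound 3 to compound 4 (0.20 log units; within the scatter) from compound 3.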

Compound 4, half-maximal inhibitory concentration: > 100000 nM
Compound 4 gave a limit, no number (the forecaster's own chance of this, stated with the estimate: 10%); at least 8.3-fold (0.92 log units) between middle value and limit.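

In this assay, chloro in place of cyclopropyl on the aromatic carbon ortho to the hydroxy group is no small change: the step is an at least 5.2-fold higher number from compound 3 to compound 4 (0.71 log units; beyond the scatter). Among the compounds shown here, earlier, the only measured step at this place was methoxy in place of hydrogen; this step shows that exchanging one group for another there also matters, with cyclopropyl giving the measurable number. Compound 4 reads only as a limit of the assay, and the full size of the step stays unknown: the limit of > 100000 nM in this assay, at which 2 of the 4 values shown sit.

On these data alone, how an amine or a carboxylic acid at this place on the core of compound 3 would read remains open, as does whether hydrogen there would give a lower number than cyclopropyl.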